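The source may hold more compounds than are shown below. What is called first, only, known or untested is meant among the compounds shown, and "the series" means these compounds.

Compound 1 `CC(C)(O)C#Cc1cc(C(O)(C(F)(F)F)C(F)(F)F)cnc1N1CCN(S(=O)(=O)c2ccc(N)nc2)CC1` carries a 3-hydroxy-3-methylbut-1-yn-1-yl group on the shared core. In an ADME assay (liver) for metabolic stability, with Liver microsome (Homo sapiens) as the target, using microsomes and NADPH, with a stated time of 30 min, tested at 1 uM (on this read-out higher numbers stand for fast clearance and lower numbers for slow clearance), compound 1 reports only a limit, < 14 mL.min-1.g-1. Compound 2 `Nc1ccc(S(=O)(=O)N2CCN(c3ncc(C(O)(C(F)(F)F)C(F)(F)F)cc3C#CCCO)CC2)cn1` also reports only a limit in this assay, < 14 mL.min-1.g-1. Among the measured compounds shown here, compound 3 `Nc1ccc(S(=O)(=O)N2CCN(c3ncc(C(O)(C(F)(F)F)C(F)(F)F)cc3-c3ccncc3)CC2)cn1`, which carries pyridin-4-yl on the same aromatic carbon, gives 15 mL.min-1.g-1, the only actual number among the three, since the other two values sit at the limit of < 14 mL.min-1.g-1 in this assay, at which 2 of the 3 values shown sit. The step that the two limits leave unreadable from compound 1 to compound 2 cannot be read between two limits. The steps of an at least 1.0-fold higher number from compound 1 to compound 3 (0.02 log units; that floor lies within the scatter) and an at least 1.0-fold higher number from compound 2 to compound 3 (0.02 log units; that floor lies within the scatter) are floors that lie within the scatter, so none of the three compounds can be said to differ from another in this assay.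

Compound 4 `Cc1nc2cc(-c3cc(C(O)(C(F)(F)F)C(F)(F)F)cnc3N3CCN(S(=O)(=O)c4ccc(N)nc4)CC3)ccc2o1` continues the series at that position with a change described as 2-methyl-1,3-benzoxazol-5-yl in place of pyridin-4-yl on an aromatic carbon. For the measured compounds named here, the steps that bear on it are the two exchanges at the same aromatic carbon, and both left the read-out unchanged within scatter, so no step beyond the scatter is expected for a 1.3-fold higher number from compound 3 to compound 4 (0.12 log units; within the scatter). Compound 4 is therefore estimated at 20 mL.min-1.g-1, within a range from 10 mL.min-1.g-1 to 45 mL.min-1.g-1.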

Compound 4, intrinsic clearance in microsomes: < 14 mL.min-1.g-1
Compound 4: a limit, no number; the forecaster's own chance of this, stated with the estimate: 35%; middle value at least 1.4-fold (0.15 log units) away from the limit.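

The exchange of pyridin-4-yl, with 6 heavy atoms in one aromatic ring, for 2-methyl-1,3-benzoxazol-5-yl, with 10 heavy atoms in two aromatic rings, gives an at least 1.0-fold lower number from compound 3 to compound 4 (0.02 log units; that floor lies within the scatter), so this much larger group brings no readable step at this aromatic carbon. In this assay compound 4 reports a limit and not a number, as do compound 1 and compound 2, and the steps from those two compounds to compound 4 cannot be read. This position has now carried two hydroxy-bearing alkynyl groups, a single pyridine ring and a two-ring group, yet the read-out sets none of them apart and cannot rank them, with most of the series resting at one value: the limit of < 14 mL.min-1.g-1 in this assay, at which 3 of the 4 values shown sit.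

On these data alone, how far compound 1, compound 2 and compound 4 lie from one another under that limit stays open, and so does whether the read-out at this position responds to any group at all. A carboxylic acid, a primary amine or a plain alkyl chain on the same aromatic carbon might show whether a step beyond the scatter can occur there.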